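Swapping Chloro for Methoxy on the Aryl Cap

The compounds below may be only part of what the source reports. "The series", "measured", "known", "first", "only" and "open" are said of these compounds alone.

Compound 1 `C/C(=C\c1cc(-c2ccc(C(F)(F)F)cc2)cs1)C(N)=O`: in a functional assay on A549 cells (Homo sapiens) for cytotoxicity, read by CCK-8 assay, with a stated time of 24 h (on this read-out lower numbers stand for stronger inhibition and higher numbers for weaker inhibition), compound 1 gives > 50000 nM, which is a limit.
Compound 2 `C/C(=C\c1cc(-c2ccc(Cl)cc2)cs1)C(N)=O`: in this assay compound 2 gives > 50000 nM, also a limit.

Compound 2 thus stands at the limit of > 50000 nM in this assay, at which 2 of the 2 values shown sit, with no number beneath it. Among the compounds with values here, the single measured step, a step that the two limits leave unreadable from compound 1 to compound 2, cannot be read. Compound 3 `COc1ccc(-c2csc(/C=C(\C)C(N)=O)c2)cc1` carries methoxy in place of chloro on an aromatic carbon. Within the data shown here, no measured step yields a size, so nothing points to a change beyond the scatter, and another limit is the likeliest outcome. Compound 3 is therefore expected at 60000 nM, within 20000 nM to 200000 nM. That expected step amounts to a step that the limit leaves unreadable from compound 2 to compound 3.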

Compound 3, half-maximal inhibitory concentration: > 50000 nM
Compound 3 ended at the assay's limit (the forecaster's own chance of this, stated with the estimate: 80%); the middle value does not contradict the limit.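

No step among compound 1, compound 2 and compound 3 can be read, as all three stand at a limit: the limit of > 50000 nM in this assay, at which 3 of the 3 values shown sit.

The compounds shown leave open whether trifluoromethyl, chloro and methoxy differ at all in this assay.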